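A few compounds are considered here, and "the series" means these few. Any claim that something is new, unique, unknown or untested is made for them only; others in the source may bear on it.

Measured compounds:
compound 1 `CCC(CC)(CC)C(=O)O[C@H]1C[C@@H](C)C=C2C=C[C@H](C)[C@H](CC[C@@H]3C[C@@H](O)CC(=O)O3)C21` – 1.4 nM
compound 2 `C[C@H]1C=C2C=C[C@H](C)[C@H](CC[C@@H]3C[C@@H](O)CC(=O)O3)C2[C@@H](OC(=O)C2CC2)C1` – 38.6 nM

Among the compounds with values here, in an assay for inhibition of 3-hydroxy-3-methylglutaryl-coenzyme A reductase (Rattus norvegicus) (on this read-out higher numbers stand for weaker inhibition and lower numbers for stronger inhibition), compound 2 gives 38.6 nM, the highest of the two numbers measured; its nearest neighbour is compound 1, and the only measured step, a 28-fold higher number from compound 1 to compound 2 (1.44 log units; beyond the scatter), shows that shrinking the branched acyl group to a small ring made inhibition much weaker. Compound 3 `CCCCC(=O)O[C@H]1C[C@@H](C)C=C2C=C[C@H](C)[C@H](CC[C@@H]3C[C@@H](O)CC(=O)O3)C21` is the next change on the same carbonyl carbon: butyl in place of cyclopropyl on a carbonyl carbon. Within the data shown here, a butyl chain lies between the small ring of compound 2 and the bulky branched group of compound 1 in size, so the one relevant step suggests that adding carbon back onto this position should bring the number down again, though a straight chain need not recover all of what compound 1 showed. Compound 3 is therefore expected to give 8 nM (range 2 nM to 30 nM). The expected step is a 4.8-fold lower number from compound 2 to compound 3 (0.68 log units; beyond the scatter), a moderate drop.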

Compound 3, half-maximal inhibitory concentration: 8.7 nM
Estimate against measurement, compound 3: 1.1-fold (0.04 log units) below, within the range that was stated.
By their numbers in this assay, from the lowest: compound 1; then compound 3; then compound 2.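

In this assay, the butyl compound takes a middle place: a 4.4-fold lower number from compound 2 to compound 3 (0.65 log units; beyond the scatter), yet a 6.2-fold higher number from compound 1 to compound 3 (0.79 log units; beyond the scatter). On this carbonyl carbon, an open butyl chain therefore recovers part of the inhibition lost with cyclopropyl, but not all of the level reached with 1,1-diethylpropyl. No available evidence explains this order.

The step from cyclopropyl to butyl removes a ring and also changes the carbon count, and these compounds cannot show which of the two matters more. A cyclobutyl group would keep a ring with the same number of carbons as butyl, while a tert-butyl group or a longer chain such as hexyl would help show whether branching or chain length better accounts for the stronger inhibition.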